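The compounds below may be only part of what the source reports. "The series", "measured", "known", "first", "only" and "open" are said of these compounds alone.

Measured so far:
compound 1, `COc1cc(NC(C)CCCNC(=O)NNC(=O)Nc2ccc(Br)cc2)c2ncccc2c1`, in a functional assay on MOLT-4 cells (Homo sapiens) for inhibition, read by MTT assay, with a stated time of 72 h (on this read-out lower numbers stand for stronger inhibition and higher numbers for weaker inhibition), gives 209000 nM;
compound 2, `COc1cc(NC(C)CCCNC(=O)NNC(=O)Nc2cccc(Cl)c2)c2ncccc2c1`, in this assay gives 93000 nM.

Within the data shown here, compound 2 has the lower of the two numbers; its only neighbour is compound 1, and the step between them, a 2.2-fold lower number from compound 1 to compound 2 (0.35 log units; beyond the scatter), is modest though beyond the scatter. Compound 3, `COc1cc(NC(C)CCCNC(=O)Nc2cccc(O)c2)c2ncccc2c1`, is not yet measured. It differs from compound 2 in one place: 3-hydroxyphenyl in place of ((3-chlorophenyl)carbamoyl)amino on an amide-type nitrogen. Among the measured compounds shown here, this removes a whole urea-bearing fragment rather than swapping one ring substituent for another, so the single measured step bears on it only loosely: it shows that a change at the outer aromatic ring went with a modest shift in this assay. For the measured compounds named here, with no step of the same kind available, the expectation for compound 3 is a number near that of compound 2, as a step of a 1.2-fold lower number from compound 2 to compound 3 (0.07 log units; within the scatter), with a wide range. Compound 3 is estimated at 80000 nM, between 25000 nM and 250000 nM.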

Compound 3, half-maximal inhibitory concentration: 24000 nM
Compound 3: middle estimate off by 3.3-fold (0.52 log units), on the high side, and the stated range ends above it.
By their numbers in this assay, from the lowest: compound 3; then compound 2; then compound 1.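

In this assay, replacing the whole ((3-chlorophenyl)carbamoyl)amino fragment on the amide-type nitrogen with 3-hydroxyphenyl gives a 3.9-fold lower number from compound 2 to compound 3 (0.59 log units; beyond the scatter), and the matching change from the bromine-bearing fragment gives an 8.7-fold lower number from compound 1 to compound 3 (0.94 log units; beyond the scatter) in the same direction. The earlier step, a 2.2-fold lower number from compound 1 to compound 2 (0.35 log units; beyond the scatter), only exchanged one outer ring and its halogen for another, with the urea-bearing fragment kept. The new steps show that this position accepts a much shorter group, and that the number falls rather than rises.

Whether the lower number goes with the shorter fragment or with the hydroxyl stays open, since the compounds shown do not separate the two, whereas an unsubstituted phenyl or a 3-aminophenyl on that nitrogen could. Nothing measured here explains why the numbers moved.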